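This account rests on a few compounds, and the source may have more. Where it says the series, first, only, none or still open, it means among the compounds named here.

Measured in a functional assay on MCF7 cells (Homo sapiens) for antiproliferative activity, read by CellTiter-Glo, with a stated time of 5 days; a higher number here means a weaker inhibitor, a lower number a stronger inhibitor:
- compound 1 `CC/C(=C(/c1ccc(/C=C/C(=O)O)cc1)c1ccc(-c2cnsc2)cc1)c1ccccc1`: 120 nM
- compound 2 `CC/C(=C(/c1ccc(/C=C/C(=O)O)cc1)c1ccc(-c2cc[nH]n2)cc1)c1ccccc1`: 440 nM
- compound 3 `CC/C(=C(/c1ccc(/C=C/C(=O)O)cc1)c1ccc(-c2cnn(C)c2)cc1)c1ccccc1`: 80 nM

Compound 3 shares the low end of this small set with compound 1. The data show a 1.5-fold lower number from compound 1 to compound 3 (0.18 log units; within the scatter), so these two cannot be separated, and a 5.5-fold lower number from compound 2 to compound 3 (0.74 log units; beyond the scatter), a modest gap.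

Compound 4 `CC/C(=C(/c1ccc(/C=C/C(=O)O)cc1)c1ccc(N2CCCCC2)cc1)c1ccccc1` differs from compound 3 by one change, piperidin-1-yl in place of 1-methyl-1H-pyrazol-4-yl on an aromatic carbon.

The three measured steps all happen at this same place, but each exchanges one five-membered aromatic ring for another. None of them tests a six-membered non-aromatic ring, so they offer only a rough guide to size. The smallest is a 1.5-fold lower number from compound 1 to compound 3 (0.18 log units; within the scatter), and the largest is a 5.5-fold lower number from compound 2 to compound 3 (0.74 log units; beyond the scatter). Since compound 3 at 80 nM already lies at the low end of the values seen, a modest move to a higher number seems more likely than a further fall, though the data cannot rule out a result within the scatter. The step expected in this assay is a 2.5-fold higher number from compound 3 to compound 4 (0.40 log units; beyond the scatter). The estimate for compound 4 is 200 nM, with an expected range of 70 nM to 600 nM.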

Compound 4, half-maximal inhibitory concentration: 450 nM
Estimate against measurement, compound 4: 2.3-fold (0.35 log units) below; the measured number falls inside the stated range.
By their numbers in this assay, from the lowest: compounds 3 and 1 (each within the scatter of the next); then compounds 2 and 4 (each within the scatter of the next).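

In this assay, the position on an aromatic carbon, para to a large group, now carries a six-membered non-aromatic ring, and piperidin-1-yl gives up ground to 1-methyl-1H-pyrazol-4-yl (a 5.6-fold higher number from compound 3 to compound 4 (0.75 log units; beyond the scatter)) and to 1,2-thiazol-4-yl (a 3.8-fold higher number from compound 1 to compound 4 (0.57 log units; beyond the scatter)). It cannot be told apart from 1H-pyrazol-3-yl (a 1.0-fold higher number from compound 2 to compound 4 (0.01 log units; within the scatter)), so among these four compounds the split between aromatic and non-aromatic rings does not by itself sort the values: compound 2, with its five-membered aromatic ring, goes against any such rule. Nothing available on these compounds accounts for the differences between these groups.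

As far as these compounds go, what remains open is whether the cost belongs to the piperidine ring itself or to its particular atoms, a question that a morpholin-4-yl or a piperazin-1-yl group at the same place would address. From the compounds shown here alone, it is also open whether a six-membered aromatic ring such as pyridin-4-yl or phenyl would sit with compound 3 and compound 1 or with compound 2 and compound 4.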